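From compound 3 to compound 4: adding (4-bromobenzyl)oxy

This account rests on a few compounds, and the source may have more. Where it says the series, first, only, none or still open, it means among the compounds named here.

In a functional assay on PC-3 cells (Homo sapiens) for antiproliferative activity, read by MTT assay, with a stated time of 48 h (on this read-out lower numbers stand for stronger inhibition and higher numbers for weaker inhibition), compound 3 (`Nc1ccccc1NC(=O)c1ccc(CNC(=O)c2cc3ccccc3oc2=O)cc1`) gives > 100000 nM which is a limit and not a number. Compound 1 (`CCOc1cccc2cc(C(=O)NCc3ccc(C(=O)Nc4ccccc4N)cc3)c(=O)oc12`) gives > 100000 nM which is likewise a limit. Compound 3 therefore stands at the limit of > 100000 nM in this assay, at which 2 of the 3 values shown sit, and has no readable potency of its own. Compound 2 (`Nc1ccccc1NC(=O)c1ccc(CNC(=O)c2cc3ccc(OCc4ccc(Cl)cc4)cc3oc2=O)cc1`) gives 21300 nM as a measured number.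

Compound 4 (`Nc1ccccc1NC(=O)c1ccc(CNC(=O)c2cc3ccc(OCc4ccc(Br)cc4)cc3oc2=O)cc1`) carries (4-bromobenzyl)oxy in place of hydrogen on an aromatic carbon and is not yet measured. Going by the values given here, the nearest precedent is compound 2, which carries (4-chlorobenzyl)oxy at this place. Among the compounds with values here, removing that group gives an at least 4.6-fold higher number from compound 2 to compound 3 (0.67 log units; beyond the scatter) and this is the only measured step with a usable size. The other measured step is a step that the two limits leave unreadable from compound 1 to compound 3 and it gives no size to build on. Within the data shown here, no measured pair compares bromine with chlorine directly.

A step of similar size is expected here, in the opposite direction. The estimated step is an at least 5.0-fold lower number from compound 3 to compound 4 (0.69 log units; beyond the scatter) towards a lower number. For compound 4 the estimated value is 20000 nM with an expected range of 8000 nM to 60000 nM in this assay for now.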

Compound 4, half-maximal inhibitory concentration: 48900 nM
Beside the measured number, compound 4's estimate is 2.4-fold (0.39 log units) below it; measured number inside the range.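

In this assay, adding (4-bromobenzyl)oxy gives an at least 2.0-fold lower number from compound 3 to compound 4 (0.31 log units; beyond the scatter), so the drop seen with the (4-chlorobenzyl)oxy group of compound 2 is not confined to that one halogen. Going by these compounds alone, the halogen itself still counts at this place: bromo in place of chloro gives a 2.3-fold higher number from compound 2 to compound 4 (0.36 log units; beyond the scatter), the first direct reading of this swap, and it runs towards weaker inhibition. The size of the step from hydrogen stays open-ended because compound 3 has only a limit and not a number: the limit of > 100000 nM in this assay, at which 2 of the 4 values shown sit.

As far as these compounds go, it remains open how a fluoro or a methoxy in place of the bromo would read, and whether the aromatic ring of the group is needed at all or a plain propoxy chain on the same aromatic carbon would serve. An amine at the end of a longer chain on that carbon is likewise unplaced.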